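Loss of a Chloro Group in Two Matched Pairs

The compounds below may be only part of what the source reports. "The series", "measured", "known", "first", "only" and "open" are said of these compounds alone.

Compound 1 `CCN(CC)CCNC(=O)CC(CC(=O)NC1Cc2ccccc2C1)c1ccc(Cl)cc1`: 75000 nM
Compound 2 `CCN(CC)CCNC(=O)CC(CC(=O)NC1Cc2ccccc2C1)c1ccccc1`: > 100000 nM, which is a limit of the assay
Compound 3 `CCNCCNC(=O)CC(CC(=O)N(CC)C1Cc2ccccc2C1)c1ccc(Cl)cc1`: 14400 nM

Of the compounds shown here, three have been measured in a functional assay on MCF7 cells (Homo sapiens) for inhibition; on this read-out higher numbers stand for weaker inhibition and lower numbers for stronger inhibition. Compound 1 gives 75000 nM. Compound 2 reaches only a limit of this assay, > 100000 nM, so for it only a limit and no number is known (the limit of > 100000 nM in this assay, at which 1 of the 3 values shown sits). Compound 3 gives 14400 nM, the lowest number of the two numbers given, and a step beyond the scatter from compound 1. The two cores of compound 1 and compound 3 are built from the same atoms joined differently; the difference between the two cores is not broken down here.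

The step from compound 1 to compound 2 is hydrogen in place of chloro on an aromatic carbon; it brought an at least 1.3-fold higher number from compound 1 to compound 2 (0.12 log units; that floor lies within the scatter).

Compound 4 `CCNCCNC(=O)CC(CC(=O)N(CC)C1Cc2ccccc2C1)c1ccccc1` has not yet been measured in this assay. It differs from compound 3 by hydrogen in place of chloro on an aromatic carbon, the same change that was made from compound 1 to compound 2. Because that change gave an at least 1.3-fold higher number from compound 1 to compound 2 (0.12 log units; that floor lies within the scatter), a step of similar direction, a 2.8-fold higher number from compound 3 to compound 4 (0.44 log units; beyond the scatter), is expected from compound 3 to compound 4. Compound 4 is therefore estimated to give 40000 nM, with a range from 15000 nM to 120000 nM.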

Compound 4, half-maximal inhibitory concentration: > 100000 nM
Compound 4: only a limit was reported; the forecaster's own chance of this, stated with the estimate: 30%; middle value at least 2.5-fold (0.39 log units) away from the limit.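

In this assay, the change from 4-chlorophenyl to phenyl brought an at least 6.9-fold higher number from compound 3 to compound 4 (0.84 log units; beyond the scatter). Compound 4 reaches only a limit of the assay, > 100000 nM. Both pairs therefore run towards a higher number on losing the chloro group, although only the step on the core of compound 3 is shown to lie beyond the scatter, and both phenyl compounds stand at the same limit: the limit of > 100000 nM in this assay, at which 2 of the 4 values shown sit. This supports the direction of the change on these two cores, but it does not show that the size of the step carries over from one core to the other: the same change on two cores in this assay, an at least 1.3-fold higher number (0.12 log units; that floor lies within the scatter) from compound 1 to compound 2 and an at least 6.9-fold higher number (0.84 log units; beyond the scatter) from compound 3 to compound 4; the limit leaves it open whether they differ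

The compounds shown leave open how far past the limit compound 2 and compound 4 lie. They also leave open whether another group on the aromatic carbon, such as fluoro, bromo or methoxy, would give a lower number than hydrogen on either core.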